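From hydroxy to methoxy on compound 1

The compounds below may be only part of what the source reports. "The series", "measured", "known", "first", "only" and "open" are said of these compounds alone.

- Compound 1 (`O=C(NCCCNc1cc(-c2cn(-c3ccccc3)nc2-c2cccc(O)c2)ccn1)Nc1ccc(F)cc1`) gives 5880 nM
- Compound 2 (`O=C(NCCCNc1cc(-c2cn(-c3ccccc3)nc2-c2cccc(O)c2)ccn1)Nc1cccc(C(F)(F)F)c1`) gives 8890 nM

Going by the values given here, both numbers come from a functional assay on NCI-H460 cells (Homo sapiens) for antiproliferative activity, read by sulforhodamine B assay, with a stated time of 48 h (on this read-out higher numbers stand for weaker inhibition of growth and lower numbers for stronger inhibition of growth), and they lie within the usual scatter of each other, so compound 1 stands level with its only measured neighbour. Compound 3 (`COc1cccc(-c2nn(-c3ccccc3)cc2-c2ccnc(NCCCNC(=O)Nc3ccc(F)cc3)c2)c1`) differs from compound 1 at another place (methyl in place of hydrogen on an oxygen on an aromatic ring): methyl in place of hydrogen on an oxygen on an aromatic ring, or 3-hydroxyphenyl to 3-methoxyphenyl. Among the compounds with values here, the only measured step (a 1.5-fold higher number from compound 1 to compound 2 (0.18 log units; within the scatter)) is a change on an amide-type nitrogen, not on this oxygen, so it bears on the question only loosely. Within the data shown here, no measured compound shows what this oxygen change does. Going by that small step, no change beyond the scatter is expected in this assay and no firm direction can be named. The estimated step (a 1.2-fold higher number from compound 1 to compound 3 (0.08 log units; within the scatter)) is accordingly small, with a wide range. Compound 3 is estimated at 7000 nM (expected range 2500 nM to 20000 nM).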

Compound 3, concentration for total growth inhibition: 17100 nM
Beside the measured number, compound 3's estimate is 2.4-fold (0.39 log units) below it, and the stated range covers the measured number.
By their numbers in this assay, from the lowest: compounds 1, 2 and 3 (each within the scatter of the next, the first and the last beyond it).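

In this assay, methyl in place of hydrogen on the oxygen gives a 2.9-fold higher number from compound 1 to compound 3 (0.46 log units; beyond the scatter) and so modestly weakens growth inhibition. Going by these compounds alone, this is the first measured change at this oxygen, and unlike the step on the amide-type nitrogen, which stayed within the scatter, it shows that one added carbon here can move the read-out beyond the scatter. No measurement shown explains this shift.

A single pair cannot show whether the free hydroxy itself matters or whether any group on this oxygen would give a similar result. An ethoxy group would test a longer chain on the same oxygen, while an amino group in place of the hydroxy would test a different atom at this place on the 3-hydroxyphenyl ring.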